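A few compounds are considered here, and "the series" means these few. Any claim that something is new, unique, unknown or untested is made for them only; others in the source may bear on it.

Of the compounds shown here, three have so far been measured in a functional assay on HL-60 cells (Homo sapiens) for inhibition, read by CCK-8 assay, with a stated time of 48 h; on this read-out lower numbers stand for stronger inhibition and higher numbers for weaker inhibition. Compound 1 `O=C(NCCNS(=O)(=O)c1cc(-c2ccccc2Oc2ccc(O)c(O)c2)cs1)Nc1cc(C(F)(F)F)cc(C(F)(F)F)c1` gives 1300 nM. Compound 2 `O=C(Nc1cccc([N+](=O)[O-])c1)N1CCN(S(=O)(=O)c2sccc2-c2ccccc2Oc2ccc(O)c(O)c2)CC1` gives 4500 nM. Both of these carry a core with two free hydroxyl groups, while compound 3 `O=S(=O)(NCCNC(=S)Nc1cccc(Cl)c1)c1ccc(-c2ccccc2OCc2ccccc2)s1` is built on a different core that carries a benzyloxy group instead. For compound 3 this assay does not report a number but only a limit, > 50000 nM. That is the limit of > 50000 nM in this assay, at which 1 of the 3 values shown sits, so compound 3 stands at the edge of what the measurement can resolve, and its true value is not known.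

Compound 4 `O=[N+]([O-])c1ccc(NC(=S)NCCNS(=O)(=O)c2ccc(-c3ccccc3OCc3ccccc3)s2)cc1` keeps the whole core of compound 3 and alters a single group: 4-nitrophenyl in place of 3-chlorophenyl on an amide-type nitrogen. Among the compounds with values here, no measured pair in this set differs in just that way, so no direct step can be read off. Compound 2 also carries a nitro group on its aryl ring, but on a different core and a urea rather than a thiourea, so its value cannot be carried over. Given that compound 3 sits at a limit, the step of an at least 1.2-fold lower number from compound 3 to compound 4 (0.09 log units; that floor lies within the scatter) is expected to be small and uncertain in direction. Compound 4 is therefore estimated at 40000 nM, with a range from 8000 nM to 150000 nM.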

Compound 4, half-maximal inhibitory concentration: > 50000 nM
Compound 4 ended at the assay's limit (the forecaster's own chance of this, stated with the estimate: 50%); middle value at least 1.2-fold (0.09 log units) from the limit.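

In this assay compound 4 gives > 50000 nM, which is a limit and not a number. Compound 3 gives > 50000 nM, also a limit. Within the data shown here, no step between compound 3 and compound 4 can therefore be read. The compounds shown leave open how 4-nitrophenyl and 3-chlorophenyl compare on this core, as both values stay at the edge of the measurement: the limit of > 50000 nM in this assay, at which 2 of the 4 values shown sit.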